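The source may hold more compounds than are shown below. What is called first, only, known or untested is meant among the compounds shown, and "the series" means these compounds.

Working notes on the amide series in a functional assay on PC-3 cells (Homo sapiens) for antiproliferative activity, read by MTT assay, with a stated time of 48 h; a higher number here means a weaker inhibitor, a lower number a stronger inhibitor. Compound 1 `CCn1c(C(=O)NCCCN(C)C)ccc1C(CC)(CC)c1ccc(OCCC(O)(CC)CC)c(C)c1` gives 2150 nM. Compound 2 `CCn1c(C(=O)N(CCC#N)CCC#N)ccc1C(CC)(CC)c1ccc(OCCC(O)(CC)CC)c(C)c1` reads > 50000 nM, a limit and not a number. Compound 3 `CCn1c(C(=O)NC(C)C(=O)O)ccc1C(CC)(CC)c1ccc(OCCC(O)(CC)CC)c(C)c1` gives 11700 nM, the weaker of the two true numbers, with a 5.4-fold higher number from compound 1 to compound 3 (0.74 log units; beyond the scatter). Against that limit it shows an at least 4.2-fold lower number from compound 2 to compound 3 (0.63 log units; beyond the scatter). Compound 4 `CCn1c(C(=O)N(C)CCO)ccc1C(CC)(CC)c1ccc(OCCC(O)(CC)CC)c(C)c1` changes the same carbonyl substituent: (2-hydroxyethyl)(methyl)amino in place of (1-carboxyethyl)amino on a carbonyl carbon. The bearing steps are the modest one above and the large at least 23-fold higher number from compound 1 to compound 2 (1.36 log units; beyond the scatter), since compound 2, like compound 4, lacks the amide hydrogen. That is a single case, so it shifts the expectation only slightly. In this assay the expected change stays within the scatter, leaning towards a higher number: a 1.2-fold higher number from compound 3 to compound 4 (0.08 log units; within the scatter). The estimate for compound 4 is 14000 nM, with an expected range of 4500 nM to 45000 nM.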

Compound 4, half-maximal inhibitory concentration: 3090 nM
The estimate for compound 4 lay 4.5-fold (0.66 log units) above the measured number; the whole stated range lies above it.
By their numbers in this assay, from the lowest: compounds 1 and 4 (each within the scatter of the next); then compound 3. At a limit, above all of these: compound 2.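

In this assay, loss of the amide hydrogen alone does not decide the read-out: (2-hydroxyethyl)(methyl)amino in place of (3-(dimethylamino)propyl)amino gives a 1.4-fold higher number from compound 1 to compound 4 (0.16 log units; within the scatter). The same group in place of (1-carboxyethyl)amino gives a 3.8-fold lower number from compound 3 to compound 4 (0.58 log units; beyond the scatter), so the carbonyl substituent still matters when the acid leaves. The step of an at least 16-fold lower number from compound 2 to compound 4 (1.20 log units; beyond the scatter) starts from a limit of compound 2, not a number: the limit of > 50000 nM in this assay, at which 1 of the 4 values shown sits.

Still open, as far as these compounds go, is whether the hydroxyl of the (2-hydroxyethyl)(methyl)amino group matters, as a methoxy group in its place would show. Also open, from the compounds shown here alone, is whether a dimethylamino chain on a nitrogen lacking the amide hydrogen would read like this group.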